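Swapping a Primary Amine for a Pyrrolidine Ring

This account rests on a few compounds, and the source may have more. Where it says the series, first, only, none or still open, it means among the compounds named here.

Of the compounds shown here, three sharing one core have been measured in an assay on HeLa cells for displacement of a labelled ligand from 5-hydroxytryptamine receptor 6 (Homo sapiens); on this read-out lower numbers stand for stronger inhibition and higher numbers for weaker inhibition. Compound 1 `CN(C)CCn1cc(S(=O)(=O)c2ccccc2)c2cccnc21` gives 23 nM, compound 2 `Cc1c(S(=O)(=O)c2ccccc2)c2cccnc2n1CCN` gives 4.2 nM, and compound 3 `NCCn1cc(S(=O)(=O)c2cccc(F)c2)c2cccnc21` gives 4.7 nM. Compound 3 thus stands second highest of the three: close to compound 2, within the usual scatter, and well apart from compound 1, beyond it. Compound 4 `O=S(=O)(c1cccc(F)c1)c1cn(CCN2CCCC2)c2ncccc12` differs from compound 3 in one place: pyrrolidin-1-yl in place of amino on a saturated chain carbon, two bonds along the chain from an aromatic nitrogen. Within the data shown here, no measured pair isolates exactly this change, so its effect is uncertain; compound 1, which also differs elsewhere, is the only measured compound without an amine hydrogen at the chain end and gave 23 nM. A modest loss of binding is therefore expected for compound 4, a step of a 2.6-fold higher number from compound 3 to compound 4 (0.41 log units; beyond the scatter) somewhat beyond the scatter. Compound 4 is expected to give 12 nM, between 4 nM and 35 nM.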

Compound 4, inhibition constant: 88 nM
Compound 4: the middle estimate sits 7.3-fold (0.87 log units) below what was measured; the whole stated range lies below it.
By their numbers in this assay, from the lowest: compounds 2 and 3 (each within the scatter of the next); then compound 1; then compound 4.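

In this assay the end of the chain proves far from indifferent to this change: pyrrolidin-1-yl in place of amino brings a 19-fold higher number from compound 3 to compound 4 (1.27 log units; beyond the scatter) and so a clear loss of binding. This is the first pair shown that differs only at this position, which lets the size of the change be read directly. Nothing shown explains why the step is so large. A methylamino group or a piperidine ring at the same place could show whether the loss comes with any substitution on the nitrogen or with this ring in particular.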